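Cyclotoxicity notes: amino replacements at the aryl position

The source may hold more compounds than are shown below. What is called first, only, known or untested is meant among the compounds shown, and "the series" means these compounds.

Measured compounds:
- compound 1 `CS(=O)(=O)Oc1c(C(=O)NCc2ccc(F)cc2)nc(Br)c2cccnc12`: "not determined" (no result reported) in a functional assay on MCF7 cells (Homo sapiens) for cytotoxicity, read by MTT assay, with a stated time of 72 h; a lower number here means a stronger inhibitor, a higher number a weaker inhibitor
- compound 2 `N[C@H]1CC[C@H](Nc2c(C(=O)NCc3cccs3)nc(Br)c3cccnc23)CC1`: 7300 nM in this assay

Compound 1 carries a (methylsulfonyl)oxy group on the shared core and has no number in this assay, so it cannot be placed on the scale; the only anchor for the series is compound 2, which differs from compound 1 at more than one place. In this assay compound 2 gives 7300 nM. Compound 3 `CN(C)CCCNc1c(C(=O)NCc2ccc(F)cc2)nc(Br)c2cccnc12` has not yet been measured. It differs from compound 1 as follows: (3-(dimethylamino)propyl)amino in place of (methylsulfonyl)oxy on an aromatic carbon. Within the data shown here, since compound 1 has no value, the size and direction of the step from compound 1 to compound 3 in this assay cannot be stated from the data; what is known is only that the one measured amino-substituted member, compound 2, sits in the micromolar range. Compound 3 is expected to give about 6000 nM in this assay, within a range of 1500 nM to 25000 nM, with the estimate resting on compound 2 and its value of 7300 nM.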

Compound 3, half-maximal inhibitory concentration: 7000 nM
For compound 3 the middle estimate is 1.2-fold (0.07 log units) below the measured one; low and high end bracket the measured number.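

In this assay, among these compounds, compound 1 stands as "not determined" (no result reported) and compound 3 gives 7000 nM so no step between the two can be read. The compounds shown leave open how (3-(dimethylamino)propyl)amino compares with (methylsulfonyl)oxy on the shared core. No measured property is available that bears on this result.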